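A few compounds are considered here, and "the series" means these few. Any claim that something is new, unique, unknown or untested is made for them only; others in the source may bear on it.

Measured compounds:
Compound 1, `COc1cc(/C=C/c2ccc(S(N)(=O)=O)cc2)cc(OC)c1`: 18600 nM
Compound 2, `COc1cccc(/C=C/c2ccc(S(N)(=O)=O)cc2)c1`: 10400 nM
Compound 3, `NS(=O)(=O)c1ccc(/C=C/c2ccc(O)cc2)cc1`: 4350 nM

In a functional assay on HL-60 cells (Homo sapiens) for inhibition (a lower number here means a stronger inhibitor of growth, a higher number a weaker inhibitor of growth), compound 2 stands second highest of the three numbers. Its nearest neighbour is compound 1, and that step, a 1.8-fold lower number from compound 1 to compound 2 (0.25 log units; within the scatter), comes from hydrogen in place of methoxy on an aromatic carbon. Furthest from it is compound 3, which gives 4350 nM, a lower number beyond the scatter; no single-step comparison links compound 3 to compound 2.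

Compound 4, `NS(=O)(=O)c1ccc(/C=C/c2cccc(O)c2)cc1`, has not yet been measured in this assay. It differs from compound 2 by hydrogen in place of methyl on an oxygen on an aromatic ring. Among the measured compounds shown here, no measured step shows this particular change. For the measured compounds named here, the only step on this ring, a 1.8-fold lower number from compound 1 to compound 2 (0.25 log units; within the scatter), removed a whole methoxy and stayed within the scatter, so the data give little reason to expect a large shift. Compound 3 carries a hydroxy too, but it differs from compound 4 in more than one place, so its number only suggests that a hydroxy-bearing compound can give a lower number.

The step of a 1.5-fold lower number from compound 2 to compound 4 (0.17 log units; within the scatter) is therefore expected to be modest, leaning toward a lower number. Compound 4 is estimated at 7000 nM, with a range from 2500 nM to 20000 nM.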

Compound 4, concentration for 50% growth inhibition: 41400 nM
For compound 4 the middle estimate is 5.9-fold (0.77 log units) below the measured one, outside the stated range (above it).
By their numbers in this assay, from the lowest: compound 3; then compounds 2 and 1 (each within the scatter of the next); then compound 4.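

In this assay, replacing methyl with hydrogen on an oxygen on an aromatic ring gives a 4.0-fold higher number from compound 2 to compound 4 (0.60 log units; beyond the scatter) and so makes compound 4 a weaker inhibitor of growth than compound 2. The earlier step on this ring, a 1.8-fold lower number from compound 1 to compound 2 (0.25 log units; within the scatter), removed a whole methoxy and stayed within the scatter, so it gave no sign that this ring could respond beyond the scatter; the methoxy to hydroxy change shows that it can, and that the direction is toward a higher number. No measurement shown here bears on why this small exchange moves the number in that direction.

The compounds shown leave open whether an amine or a carboxylic acid in place of the hydroxy, or a longer chain such as ethyl in place of the methyl on the oxygen, would sit nearer compound 2 or compound 4 in this assay. They also leave open whether the same methoxy to hydroxy change would give a step of similar size and direction when made on compound 1, which carries a second methoxy on the ring.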